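The source may report more compounds than this note shows. Statements on the series, on what has been measured and on what is new or still open speak of the compounds shown alone.

Measured so far in a toxicity assay on the whole organism with Mus musculus as the target, in the rotarod test; on this read-out higher numbers stand for an effect only at larger amounts of compound and lower numbers for an effect already at smaller amounts:
- compound 1 `CC1(C)C(=O)NC(c2ccccc2N)c2ccccc21`: > 1000 mg/kg
- compound 2 `CNCC(=O)Nc1ccc(C2NC(=O)C(C)(C)c3ccccc32)cc1`: 600 mg/kg

In this assay, among the compounds with values here, compound 2 gives 600 mg/kg, and this is the only number in the set. The further value shown, that of compound 1, is a limit of the assay and not a number. Compound 1 sits at the limit of > 1000 mg/kg in this assay, at which 1 of the 2 values shown sits. Within the data shown here, because the two compounds differ in more than one place, no step between measured compounds can be read from them, and the pair says nothing about the size of any single change.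

Compound 3 `CC1(C)C(=O)NC(c2ccc(NC(=O)CN)cc2)c2ccccc21` is not yet measured. It differs from compound 2 in one place: hydrogen in place of methyl on an amine nitrogen. With no measured step of this kind in the series, the expectation rests on the value of compound 2 alone. The step from compound 2 to compound 3 is expected to be no change at the digits printed from compound 2 to compound 3 (within the scatter), with no direction beyond the usual scatter. For compound 3 the estimate in this assay is 600 mg/kg, expected between 300 mg/kg and 1200 mg/kg.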

Compound 3, dose for half-maximal effect: 420 mg/kg
Compound 3: the middle estimate sits 1.4-fold (0.15 log units) above what was measured, and the stated range covers the measured number.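

Within the data shown here, the exchange of methyl for hydrogen on an amine nitrogen, here one whose other neighbour is a saturated chain carbon, gives the first step that can be read: in this assay it comes to a 1.4-fold lower number from compound 2 to compound 3 (0.15 log units; within the scatter). Methylamino and amino at this place are therefore not told apart by this read-out, and the methyl group can be removed without the result leaving the usual scatter, which compounds 1 and 2 alone could not show. The value of compound 1 is a limit of the assay, and the steps to it cannot be read: the limit of > 1000 mg/kg in this assay, at which 1 of the 3 values shown sits.

Still open, going by these compounds, is whether a larger group on this nitrogen, such as ethyl, isopropyl or a second methyl in a dimethylamino group, would give a step beyond the scatter, as this single pair covers only methyl and hydrogen. Equally open, on these data alone, is how the read-out responds when the (aminomethyl)carbonyl group gives way to a longer chain between the carbonyl and the amine, or when a carboxylic acid takes the place of the amine.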